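From Phenyl to Allyl on a Shared Core

A few compounds are considered here, and "the series" means these few. Any claim that something is new, unique, unknown or untested is made for them only; others in the source may bear on it.

Measured in a functional assay on MCF7 cells (Homo sapiens) for cytotoxicity, read by MTT assay, with a stated time of 48 h; a higher number here means a weaker inhibitor, a lower number a stronger inhibitor:
- Compound 1 `O=[N+]([O-])c1ccc(NC(=S)N/N=C\c2ccnc3ccccc23)cc1`: 810 nM
- Compound 2 `S=C(N/N=C\c1ccnc2ccccc12)Nc1ccccc1`: 1070 nM
- Compound 3 `S=C(N/N=C\c1ccnc2ccccc12)Nc1cccc2ccccc12`: 880 nM

Compound 2 gives 1070 nM, which lies within the scatter of the values for both compound 1 and compound 3, so these numbers do not separate it from either neighbour. The unmeasured compound 4 `C=CCNC(=S)N/N=C\c1ccnc2ccccc12` differs from compound 2 in one place: allyl in place of phenyl on an amide-type nitrogen. This puts allyl in place of phenyl on an amide-type nitrogen.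

Within the data shown here, only one measured step touches that phenyl group: a 1.3-fold higher number from compound 1 to compound 2 (0.12 log units; within the scatter). That step swaps a group on the ring but keeps the ring itself. Compound 3 carries a different aromatic group on that nitrogen and gives 880 nM. Every measured compound keeps an aromatic ring there, so the data do not show what happens when it is removed. A modest move to a higher number in this assay, meaning a weaker inhibitor, is therefore a cautious expectation, with real uncertainty in both directions. The expected change is a 1.4-fold higher number from compound 2 to compound 4 (0.15 log units; within the scatter). Compound 4 is estimated at 1500 nM, with an expected range from 500 nM to 4500 nM.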

Compound 4, half-maximal inhibitory concentration: 970 nM
Compound 4: middle estimate off by 1.5-fold (0.19 log units), on the high side; low and high end bracket the measured number.
By their numbers in this assay, from the lowest: compounds 1, 3, 4 and 2 (each within the scatter of the next).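

Swapping phenyl for allyl on the amide-type nitrogen, with the rest of the molecule unchanged, gives a 1.1-fold lower number from compound 2 to compound 4 (0.04 log units; within the scatter) in this assay, so this change does not separate the two compounds. This is the first compound shown with no aromatic ring at this place: the earlier compounds varied only what was on or fused to the ring, whereas here a ring-free group of 3 heavy atoms, with a double bond, stands in place of the phenyl group of 6 heavy atoms, and the cell result stays within the scatter. No measurement is available to explain this result.

The compounds shown leave open how far this tolerance extends, for instance whether a longer chain such as hexyl, or a chain ending in an amine or a carboxylic acid, would also stay within the scatter on this nitrogen. They also leave open whether the double bond of allyl matters, a question that the saturated propyl group would address directly in the same assay.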